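A few compounds are considered here, and "the series" means these few. Any claim that something is new, unique, unknown or untested is made for them only; others in the source may bear on it.

Going by the values given here, only two compounds have been measured so far in a functional assay on MCF7 cells (Homo sapiens) for inhibition, read by MTT assay, with a stated time of 5 days (a higher number here means a weaker inhibitor, a lower number a stronger inhibitor), and their numbers lie well apart. Compound 2 (`Cc1cc(Nc2nc(NCc3ccc(F)cc3F)nc3c2cnn3C2CCOCC2)n[nH]1`) stands lowest at 360 nM while compound 1 (`Cc1cc(Nc2nc(NCc3ccc(Cl)cc3)nc3c2cnn3CC(C)(C)O)n[nH]1`) reads 1940 nM and this gap is beyond the usual scatter. Compound 3 (`Cc1cc(Nc2nc(NCc3ccc(F)cc3F)nc3c2cnn3CC(C)(C)O)n[nH]1`) differs from compound 2 in one place, with 2-hydroxy-2-methylpropyl in place of oxan-4-yl on an aromatic nitrogen. Among the compounds with values here, no measured pair shows this change on its own, so any forecast rests on thin evidence. Within the data shown here, the only guide is compound 1, which carries the same 2-hydroxy-2-methylpropyl and gives 1940 nM but also differs from compound 2 elsewhere. Its number hints that the swap may cost some strength without showing how much. In this assay a moderate rise in the number is therefore expected, pointing to a weaker inhibitor, with a size somewhat beyond the scatter. The estimated change is a 2.4-fold higher number from compound 2 to compound 3 (0.37 log units; beyond the scatter) for this swap. For compound 3 the estimated value is 850 nM with an expected range from 300 nM to 2200 nM once it is measured.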

Compound 3, half-maximal inhibitory concentration: 160 nM
For compound 3 the middle estimate is 5.3-fold (0.73 log units) above the measured one; the whole stated range lies above it.
By their numbers in this assay, from the lowest: compound 3; then compound 2; then compound 1.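

Going by these compounds alone, compounds 2 and 3 form the first pair that isolates the group on the aromatic nitrogen. In this assay the swap to 2-hydroxy-2-methylpropyl from oxan-4-yl gives a 2.3-fold lower number from compound 2 to compound 3 (0.35 log units; beyond the scatter) and so shows that this position accepts an open chain with a hydrogen-bond donor in place of a ring without one, with a modest gain in strength. With 2-hydroxy-2-methylpropyl held fixed, the swap to 2,4-difluorophenyl from 4-chlorophenyl gives a 12-fold lower number from compound 1 to compound 3 (1.08 log units; beyond the scatter) in the same assay, a large step that separates the effect of the aryl group from that of the nitrogen substituent; nothing measured here explains why either change moves the number as it does.

Going by these compounds, it remains open whether the hydroxyl group of 2-hydroxy-2-methylpropyl matters, which a plain 2-methylpropyl group or a chain ending in an amine on the same nitrogen would help to test. It is also unknown whether the aryl step would keep its size with oxan-4-yl on that nitrogen, or whether the two changes simply add up in other compounds of this series.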